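Thiosemicarbazone series: ring amine replacing dimethylamino on pyrazine core

The compounds below may be only part of what the source reports. "The series", "measured", "known", "first", "only" and "open" are said of these compounds alone.

Compound 1 `C/C(=N\NC(=S)N(C)C)c1ccccn1`: 0.22 nM
Compound 2 `C/C(=N\NC(=S)N1CCCC1)c1ccccn1`: 0.36 nM
Compound 3 `C/C(=N\NC(=S)N(C)C)c1cnccn1`: 0.073 nM

Of the compounds shown here, three have been measured in an ADME assay on 41M cells (Homo sapiens) for cytotoxicity, read by MTT assay, with a stated time of 96 h; a higher number here means a weaker inhibitor, a lower number a stronger inhibitor. Compound 3 gives the lowest number of the three; its nearest neighbour is compound 1, which gives a number higher by a margin beyond the scatter, and compound 2 stands further away still. Compound 3 is therefore the strongest inhibitor among the measured compounds.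

Compound 4 `C/C(=N\NC(=S)N1CCCCC1)c1cnccn1` is not yet measured. It differs from compound 3 in one place: piperidin-1-yl in place of dimethylamino on a thiocarbonyl carbon. The closest measured precedent is the step on the core of compound 1, where the same dimethylamino group was replaced by a five-membered ring amine: a 1.6-fold higher number from compound 1 to compound 2 (0.21 log units; within the scatter). That step stayed within the scatter. For the measured compounds named here, the present change enters a six-membered ring rather than a five-membered one, and no measured pair shows exactly this substitution, so the precedent is indirect.

On this basis compound 4 is expected to stay close to compound 3 in this assay, with at most a small move towards a higher number, an estimated step of a 1.6-fold higher number from compound 3 to compound 4 (0.22 log units; within the scatter). Compound 4 is estimated at 0.12 nM, within a range from 0.04 nM to 0.4 nM.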

Compound 4, half-maximal inhibitory concentration: 0.41 nM
Compound 4: middle estimate off by 3.4-fold (0.53 log units), on the low side, and the stated range ends below it.
By their numbers in this assay, from the lowest: compound 3; then compounds 1, 2 and 4 (each within the scatter of the next).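

In this assay, piperidin-1-yl in place of dimethylamino on a thiocarbonyl carbon gives a 5.6-fold higher number from compound 3 to compound 4 (0.75 log units; beyond the scatter), so on the core of compound 3 this position does respond to a ring amine, which the earlier step on the core of compound 1, a 1.6-fold higher number from compound 1 to compound 2 (0.21 log units; within the scatter), did not show. Those two steps differ in both the entering ring amine and the core, so the compounds shown cannot say which of the two sets the difference in size, and the tolerance seen with pyrrolidin-1-yl does not carry over to this change. Dimethylamino on the core of compound 3 remains the lowest number of the series, and nothing measured so far bears on why the ring amine step is this large.

As far as these compounds go, it remains open whether pyrrolidin-1-yl on the core of compound 3, or piperidin-1-yl on the core of compound 1, would follow the step seen on the same core or the one seen on the other. Also open, from the compounds shown here alone, is how morpholin-4-yl, a ring carrying a second hetero atom, or diethylamino, an open amine with longer chains, would behave on the thiocarbonyl carbon.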